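Sulfonamide aryl exchange on a shared pyrrolopyrimidine-type series

This account rests on a few compounds, and the source may have more. Where it says the series, first, only, none or still open, it means among the compounds named here.

Measured compounds:
Compound 1, `N#Cc1c(-c2ccccc2)cn(-c2ccc(S(=O)(=O)Nc3ccccn3)cc2)c1N1C(=O)CCC1=O`, 5360 nM
Compound 2, `Nc1nc(=O)[nH]c2c1c(-c1ccccc1)cn2-c1ccc(S(=O)(=O)Nc2ccccn2)cc1`, 4300 nM
Compound 3, `Nc1nc(=S)[nH]c2c1c(-c1ccccc1)cn2-c1ccc(S(=O)(=O)Nc2nccs2)cc1`, 4120 nM

Of the compounds shown here, three have been tested in a functional assay on HepG2 cells (Homo sapiens) for inhibition, read by sulforhodamine B assay, with a stated time of 24 h; on this read-out lower numbers stand for stronger inhibition and higher numbers for weaker inhibition. Compound 3 carries the lowest of the three numbers, with 4120 nM, but this gives it no rank: compound 2 with 4300 nM sits within the scatter of it, and so does compound 1 with 5360 nM. On the numbers shown, the three compounds cannot be told apart.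

The next compound, compound 4, `Nc1nc(=S)[nH]c2c1c(-c1ccccc1)cn2-c1ccc(S(=O)(=O)Nc2ccccn2)cc1`, is reached from compound 3 by a single change: pyridin-2-yl in place of 1,3-thiazol-2-yl on a sulfonamide nitrogen. The rest of the molecule, including the thione-bearing core of compound 3, is kept. Compound 2 also carries a pyridin-2-yl on the sulfonamide nitrogen, but it differs from compound 3 in a second place as well, so its number and that of compound 3 only show that both lie close together.

Among the compounds with values here, with no single-change step available, and with all three measured values within the scatter of one another, no movement beyond the scatter is expected in this assay for compound 4; the step from compound 3 to compound 4 is estimated as a 1.0-fold higher number from compound 3 to compound 4 (0.02 log units; within the scatter). Compound 4 is therefore expected to give about 4300 nM, with a range from 2000 nM to 9500 nM.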

Compound 4, half-maximal inhibitory concentration: 4100 nM
Compound 4: the middle estimate sits 1.0-fold (0.02 log units) above what was measured, within the range that was stated.
By their numbers in this assay, from the lowest: compounds 4, 3, 2 and 1 (each within the scatter of the next).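

In this assay, within the data shown here, the exchange on the sulfonamide nitrogen now has a direct reading for the first time: pyridin-2-yl in place of 1,3-thiazol-2-yl gives a 1.0-fold lower number from compound 3 to compound 4 (0.00 log units; within the scatter). Among these compounds, at this position, with the thione-bearing core held constant, a five-membered aromatic ring and a six-membered aromatic ring therefore cannot be told apart in this assay, whereas the earlier compounds differed in more than one place and could not isolate this change. No measurement bears on why the two groups give such similar numbers.

On these data alone, the two groups compared are both aromatic rings, so it remains open whether a different kind of substituent on the sulfonamide nitrogen, such as a methyl group, a longer alkyl chain or a phenyl ring carrying a carboxylic acid, would move the number beyond the scatter. As far as these compounds go, it is also open whether the exchange would read the same on the core of compound 2 or with other groups elsewhere on the shared core, such as a primary amine on the phenyl ring.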